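A methyl on the ring of compound 3

The source may hold more compounds than are shown below. What is called first, only, known or untested is meant among the compounds shown, and "the series" means these compounds.

Measured so far in a functional assay for antagonist activity, with Cavia porcellus as the target (on this read-out lower numbers stand for stronger inhibition and higher numbers for weaker inhibition), each value being a limit of the assay:
Compound 1 `CCN(CC)CC#CCCC1SCCCS1` gives > 10000000 nM as a limit
Compound 2 `CN(C)CC#CCCC1SCCCS1` gives > 10000000 nM as a limit
Compound 3 `C(#CCN1CCCCC1)CCC1SCCCS1` gives > 10000000 nM as a limit

Compound 3 stands at > 10000000 nM in this assay, which is a limit and not a number. It shares this position with the other two compounds, as the series shows the limit of > 10000000 nM in this assay, at which 3 of the 3 values shown sit, and no measured number yet.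

Compound 4 `CC1CCN(CC#CCCC2SCCCS2)CC1` carries a single change from compound 3, (methyl in place of hydrogen on a saturated ring carbon), in words methyl in place of hydrogen on a saturated ring carbon. Among the compounds with values here, the only measured step is a step that the two limits leave unreadable from compound 1 to compound 2 and it offers no size to carry over. It also lies at a different place in the structure, so it gives no guide to the size or direction of this change.

The expectation therefore rests on the limit held by all three measured compounds, and no step beyond the usual scatter can be forecast. The estimated step is a number no higher from compound 3 to compound 4 (the limit leaves the size open) and it is expected to remain unreadable if a limit is reported again. For compound 4 the expected value in this assay is 10000000 nM, with an estimated range from 2000000 nM to 30000000 nM and most likely only a limit.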

Compound 4, antagonist equilibrium constant: > 10000 nM
Compound 4: only a limit was reported; the forecaster's own chance of this, stated with the estimate: 80%; the middle value does not contradict the limit.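

In this assay compound 4 gives > 10000 nM, which is a limit of the assay and not a number. Compound 3 gives > 10000000 nM, again a limit. No step can be read between compound 3 and compound 4. The compounds shown leave open what size or direction the methyl change has, as none of them yet has a measured number.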